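Removing one aromatic fluoro from compound 2

The source may report more compounds than this note shows. Statements on the series, on what has been measured and on what is new or still open speak of the compounds shown alone.

In a functional assay on the whole organism with Rattus norvegicus as the target; a higher number here means that more compound is needed for the effect, a lower number that less compound is needed:
- compound 1 `CNC(=O)/C=C1\CCc2cc(F)c(F)cc21`: 11 mg/kg
- compound 2 `NC(=O)/C=C1\CCc2cc(F)c(F)cc21`: 17 mg/kg

Within the data shown here, compound 2 stands level with compound 1, the only other measured compound, with a 1.5-fold higher number from compound 1 to compound 2 (0.19 log units; within the scatter). Compound 3 `NC(=O)/C=C1\CCc2ccc(F)cc21` differs from compound 2 by hydrogen in place of fluoro on an aromatic carbon. Among the measured compounds shown here, no measured step covers this kind of change. The one available, a 1.5-fold higher number from compound 1 to compound 2 (0.19 log units; within the scatter), lies on an amide-type nitrogen and bears on it only loosely. As far as these compounds go, no step beyond the scatter is therefore expected in this assay, and the direction stays open. The estimated outcome is a 1.2-fold higher number from compound 2 to compound 3 (0.07 log units; within the scatter). For compound 3 the expected value is 20 mg/kg, within an estimated range of 9 mg/kg to 45 mg/kg.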

Compound 3, dose for half-maximal effect: 20 mg/kg
Estimate against measurement, compound 3: no gap at the digits printed; low and high end bracket the measured number.
By their numbers in this assay, from the lowest: compounds 1, 2 and 3 (each within the scatter of the next).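

Hydrogen in place of fluoro on an aromatic carbon ortho to a fluoro group gives a 1.2-fold higher number from compound 2 to compound 3 (0.07 log units; within the scatter) in this assay and shows that this ring position, which the earlier step on the amide-type nitrogen did not touch, can lose its fluoro with the number staying level. Compound 3 keeps one fluoro, so the series now reads flat across two separate places of change. Still open, as far as these compounds go, is whether the remaining fluoro can also be replaced by hydrogen, and how a chloro or a methoxy group would read at this position. No supporting measurement bears on why the number stays level with this change.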